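Adding a nitro group to compound 3

This account rests on a few compounds, and the source may have more. Where it says the series, first, only, none or still open, it means among the compounds named here.

Measured so far in an ADME assay on a cell-free system (plasma, Homo sapiens) for protein binding, read by LC-MS, with a stated time of 5 h, tested at 10 uM:
Compound 1 `OC[C@H]1O[C@H](Oc2ccc(-n3ccc4ccccc43)cc2Cl)[C@@H](O)[C@@H](O)[C@@H]1O`: 98%
Compound 2 `O=[N+]([O-])c1ccc2c(ccn2-c2ccc(O[C@H]3O[C@H](CO)[C@@H](O)[C@H](O)[C@@H]3O)c(Cl)c2)c1`: 99%
Compound 3 `OC[C@H]1O[C@H](Oc2ccc(-n3ccc4ccccc43)cc2F)[C@@H](O)[C@@H](O)[C@@H]1O`: 98%

Compound 3 reads 98%, the same figure as compound 1 at the precision reported. Swapping chloro for fluoro gives no change at the digits printed from compound 1 to compound 3 (within the scatter). Compound 2 reads 99%.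

Compound 4 `O=[N+]([O-])c1ccc2c(ccn2-c2ccc(O[C@H]3O[C@H](CO)[C@@H](O)[C@H](O)[C@@H]3O)c(F)c2)c1` keeps the fluoro of compound 3 and differs from it in one place: nitro in place of hydrogen on an aromatic carbon. This is nitro in place of hydrogen on an aromatic carbon.

One measured step is the same change made on the chloro compound: a 2.0-fold lower unbound fraction from compound 1 to compound 2 (0.30 log units; within the scatter). The chloro-to-fluoro step also bears on the question, since it showed no difference between those two compounds. A step of similar size and direction is therefore expected in this assay, one that stays within the scatter.

The estimated step is a 2.0-fold lower unbound fraction from compound 3 to compound 4 (0.30 log units; within the scatter). For compound 4 the expected value is 99%, with an estimated range from 97% to 99.7%.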

Compound 4, plasma protein binding in the plasma assay: 95%
Beside the measured number, compound 4's estimate is 5.0-fold (0.70 log units) (unbound fraction) below it; the measured number lies below the stated range.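

In the plasma assay the nitro group on the fluoro compound gives a 2.5-fold higher unbound fraction from compound 3 to compound 4 (0.40 log units; beyond the scatter), so its outcome depends on which halogen the core carries: the same change on two cores in the plasma assay, a 2.0-fold lower unbound fraction (0.30 log units; within the scatter) from compound 1 to compound 2 and a 2.5-fold higher unbound fraction (0.40 log units; beyond the scatter) from compound 3 to compound 4, 5.0-fold (0.70 log units) apart, beyond the scatter of two such steps

Read the other way, the halogen matters in the plasma assay only once the nitro group is present, with a 5.0-fold higher unbound fraction from compound 2 to compound 4 (0.70 log units; beyond the scatter): the same change on two cores in the plasma assay, no change at the digits printed (within the scatter) from compound 1 to compound 3 and a 5.0-fold higher unbound fraction (0.70 log units; beyond the scatter) from compound 2 to compound 4, 5.0-fold (0.70 log units) apart, beyond the scatter of two such steps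

In a physicochemical assay for lipophilicity, using the shake flask method, in phosphate buffer, measured as octanol-water partition, with a stated time of 2 h, at pH 7.4, tested at 1 uM (on this read-out higher numbers stand for higher lipophilicity and lower numbers for lower lipophilicity), compound 3 reads 2.4 and compound 4 reads 1.9. In the physicochemical assay the nitro group on the fluoro core comes with a measured drop in lipophilicity, alongside the rise in free compound: the measured distribution coefficient of compound 3, 2.4, and of compound 4, 1.9, a number 0.50 log units lower (beyond the scatter)

The link between these two read-outs rests on a single pair, compound 3 and compound 4. On these data alone, whether another group at this place on the ring, such as an amine or a carboxylic acid, would also behave differently on the fluoro and chloro cores remains open.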